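Swapping a chloro for a methyl on a fused core

This account rests on a few compounds, and the source may have more. Where it says the series, first, only, none or still open, it means among the compounds named here.

Measured compounds and their growth-inhibition values:
- compound 1, `Cc1cn2c(/C=N/NC(=N)N)c(-c3ccncc3)nc2s1`: 16200 nM
- compound 2, `Cc1sc2nc(-c3ccccn3)c(/C=N/NC(=N)N)n2c1C`: 20900 nM
- compound 3, `N=C(N)N/N=C/c1c(-c2ccccn2)nc2sc(Cl)cn12`: 5620 nM

In a functional assay on CNS cells (Homo sapiens) for antiproliferative activity (a lower number here means a stronger inhibitor of growth, a higher number a weaker inhibitor of growth), compound 3 has the lowest of the three numbers; compound 1 and compound 2 both lie beyond the scatter from it. The next compound, compound 4 with the structure `Cc1cn2c(/C=N/NC(=N)N)c(-c3ccccn3)nc2s1`, differs from compound 3 by methyl in place of chloro on an aromatic carbon. Among the measured compounds shown here, no measured pair shows this exact swap, but compound 1 and compound 2, which both carry methyl at that position, give weaker inhibition than compound 3. Compound 4 is therefore expected to lose some potency, a step of a 2.1-fold higher number from compound 3 to compound 4 (0.33 log units; beyond the scatter) in this assay. The estimated value for compound 4 is 12000 nM, with a likely range from 4000 nM to 35000 nM.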

Compound 4, concentration for 50% growth inhibition: 8130 nM
Compound 4: the middle estimate sits 1.5-fold (0.17 log units) above what was measured; low and high end bracket the measured number.
By their numbers in this assay, from the lowest: compounds 3, 4, 1 and 2 (each within the scatter of the next, the first and the last beyond it).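

In this assay, chloro and methyl on this aromatic carbon, next to the ring sulfur, give values that cannot be told apart (a 1.4-fold higher number from compound 3 to compound 4 (0.16 log units; within the scatter)). Hydrogen in place of methyl on an aromatic carbon gives a clearer step (a 2.6-fold lower number from compound 2 to compound 4 (0.41 log units; beyond the scatter)), whereas pyridin-2-yl in place of pyridin-4-yl gives a step that stays within the scatter (a 2.0-fold lower number from compound 1 to compound 4 (0.30 log units; within the scatter)). No supporting evidence bears on these results.

On these data alone, whether an amine, a carboxylic acid or a longer chain at this position would change growth inhibition remains open. Also open, as far as these compounds go, is how pyridin-4-yl would compare with pyridin-2-yl when chloro sits on the core.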